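Working notes: two measured amides and one ethyl analogue

The compounds below may be only part of what the source reports. "The series", "measured", "known", "first", "only" and "open" are said of these compounds alone.

Measured so far:
compound 1 `CCc1cccc(NC(=O)CN2CCN(c3ccccn3)CC2)c1` with 370 nM
compound 2 `Cc1cccc(NC(=O)CN2CCN(c3ccc(Cl)cn3)CC2)c1` with 7780 nM

In an assay on cells for antagonist activity at D(4) dopamine receptor (Homo sapiens), read by luminescence and beta-arrestin recruitment, with a stated time of 90 min (on this read-out higher numbers stand for weaker inhibition and lower numbers for stronger inhibition), compound 1 gives 370 nM, and in this assay compound 2 gives 7780 nM. Compound 2 therefore stands at the higher of the two numbers, and its gap to compound 1 lies beyond the scatter. Compound 1 and compound 2 differ in two places at once, so no single change can be read off from them.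

Compound 3 `CCc1cccc(NC(=O)CN2CCN(c3ccc(Cl)cn3)CC2)c1` is obtained from compound 2 by one change: methyl in place of hydrogen on a saturated chain carbon bound to an aromatic carbon. Within the data shown here, no measured pair shows this change on its own. The expectation for compound 3 is a modest step downward from compound 2, a 2.6-fold lower number from compound 2 to compound 3 (0.41 log units; beyond the scatter), since compound 1, which also carries the ethyl group, gives 370 nM. Compound 3 is estimated at 3000 nM, within a range from 800 nM to 12000 nM.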

Compound 3, half-maximal inhibitory concentration: 10400 nM
For compound 3 the middle estimate is 3.5-fold (0.54 log units) below the measured one; the measured number falls inside the stated range.
By their numbers in this assay, from the lowest: compound 1; then compounds 2 and 3 (each within the scatter of the next).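

In this assay, the change from 3-methylphenyl to 3-ethylphenyl with the chloro group present gives a 1.3-fold higher number from compound 2 to compound 3 (0.13 log units; within the scatter) and so does not separate these two compounds. With 3-ethylphenyl held fixed, chloro in place of hydrogen on an aromatic carbon gives a 28-fold higher number from compound 1 to compound 3 (1.45 log units; beyond the scatter) as a large step, so among the compounds that can be compared in one place the large gap goes with the chloro group and not with the methyl to ethyl change. Nothing at hand bears on why either step has this size.

Still open, going by these compounds, is whether methyl to ethyl reads the same without the chloro group, and whether the chloro step holds with 3-methylphenyl. Also open, on these data alone, is how a longer chain such as propyl at this position, or fluoro or methoxy in place of chloro, would read.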